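Ethyl in Place of Bromo on the Fused Ring

The compounds below may be only part of what the source reports. "The series", "measured", "known", "first", "only" and "open" are said of these compounds alone.

In an assay on isolated protein for inhibition of tyrosine-protein kinase receptor UFO (Homo sapiens), read by FRET and Z'-LYTE, with a stated time of 1.5 h (on this read-out lower numbers stand for stronger inhibition and higher numbers for weaker inhibition), compound 1 `Cc1c(C(=O)Nc2ccc(Oc3ncnc4[nH]cc(-c5ccccc5)c34)c(F)c2)c(=O)c2cc(Br)ccc2n1C` gives 3120 nM, the highest number among the three compounds measured. Compound 2 `Cc1ccc2c(c1)c(=O)c(C(=O)Nc1ccc(Oc3ncnc4[nH]cc(-c5ccccc5)c34)c(F)c1)cn2C` gives 150 nM in this assay, and compound 3 `CCc1c(C(=O)Nc2ccc(Oc3ncnc4[nH]cc(-c5ccccc5)c34)c(F)c2)c(=O)c2cc(C)ccc2n1C` gives 78 nM; both of these carry a methyl on the fused six-membered carbon ring where compound 1 carries its bromo. Among the measured compounds shown here, the only step between measured compounds that differ in one place is a 1.9-fold lower number from compound 2 to compound 3 (0.28 log units; within the scatter), and it concerns an ethyl placed on the other ring of the core, not the position changed here.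

Compound 4 `CCc1ccc2c(c1)c(=O)c(C(=O)Nc1ccc(Oc3ncnc4[nH]cc(-c5ccccc5)c34)c(F)c1)c(C)n2C`, not yet measured, differs from compound 1 by ethyl in place of bromo on an aromatic carbon. For the measured compounds named here, no measured step covers this exact exchange. What the numbers do show is that compound 2 and compound 3, each with a small alkyl at this place, sit far below compound 1.

Because compound 2 gives 150 nM and compound 3 gives 78 nM with a methyl at that place, compound 4 with an ethyl there is expected to land near them rather than near compound 1. The expected step is therefore a 16-fold lower number from compound 1 to compound 4 (1.19 log units; beyond the scatter), a sizeable fall beyond the scatter. Compound 4 is estimated at 200 nM in this assay, with a range from 50 nM to 800 nM.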

Compound 4, half-maximal inhibitory concentration: 6 nM
Beside the measured number, compound 4's estimate is 33-fold (1.52 log units) above it; measured number outside the range, below it.
By their numbers in this assay, from the lowest: compound 4; then compounds 3 and 2 (each within the scatter of the next); then compound 1.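

With the rest of the structure held fixed, the exchange of bromo for ethyl on this aromatic carbon gives, in this assay, a 520-fold lower number from compound 1 to compound 4 (2.72 log units; beyond the scatter) and so ties a large change to this one place, although only one heavy atom is added and no hydrogen-bond donor or acceptor enters or leaves. The earlier compounds shown here could not show this: compound 2 and compound 3 each stand apart from compound 1 in two places, so their lower numbers left unsettled how much of the gap belonged to the bromo. Among the compounds shown here, the one earlier step, a 1.9-fold lower number from compound 2 to compound 3 (0.28 log units; within the scatter), concerned a different place and stayed within the scatter, so this position is the first where a single change is seen to move the number beyond it.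

On this background the compounds shown hold only bromo and ethyl at this place, which leaves open whether the fall comes from losing the bromo or from gaining the ethyl, and how a hydrogen, a propyl chain or an amine there would read. Nothing given here bears on why this single exchange has so large an effect.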